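The compounds below may be only part of what the source reports. "The series", "measured", "known", "first", "only" and "open" are said of these compounds alone.

Measured so far in an ADME assay on RAW264.7 cells (Mus musculus) for cytotoxicity, read by MTT assay, with a stated time of 72 h, tested at 50 ug/mL; a higher number here means more inhibition at the concentration tested (going by the name of the read-out), a lower number less inhibition:

Compound 1 `CC(=O)c1ccc(N2CCN(C(=O)c3nc4cc(Cl)ccc4s3)CC2)cc1` gives 30.8%.
Compound 2 `CN1CCN(C(=O)c2nc3cc(C(F)(F)F)ccc3s2)CC1` gives 12.6%.
Compound 3 `CCOC(=O)c1nc2cc(C(F)(F)F)ccc2s1` gives 29.1%.

Among these three, compound 2 stands lowest, with compound 3 nearest and compound 1 furthest, both gaps beyond the scatter. The compound still to be measured is compound 4 `CC(=O)c1ccc(N2CCN(C(=O)c3nc4cc(C(F)(F)F)ccc4s3)CC2)cc1`. Going from compound 2 to compound 4, the structure changes in one place: 4-acetylphenyl in place of methyl on an amine nitrogen in a ring.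

Among the measured compounds shown here, only one measured step touches compound 2, and it alters the same carbonyl-attached position in a different way: a number 16.5 percentage points higher from compound 2 to compound 3 (beyond the scatter). For the measured compounds named here, no step connects compound 1 to compound 4, yet compound 1 carries the same 4-acetylphenyl group on the same ring nitrogen and shows the highest number of the three. Both observations point the same way, so a rise beyond the scatter is expected, roughly the size of the step already seen: a number 17.4 percentage points higher from compound 2 to compound 4 (beyond the scatter). For compound 4 the estimate is 30%, within 18% to 42%.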

Compound 4, a percentage reported as inhibition, at one concentration (the size of the read-out at that concentration, not a potency): 30.6%
For compound 4 the middle estimate is 0.6 percentage points below the measured one; the range from low to high includes it.
By their numbers in this assay, from the lowest: compound 2; then compounds 3, 4 and 1 (each within the scatter of the next).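

In this assay, the ring nitrogen of the piperazine-type ring responds to what it carries: with 4-acetylphenyl in place of methyl, there is a number 18 percentage points higher from compound 2 to compound 4 (beyond the scatter). The substituent on the aromatic carbon of the shared core behaves differently in this one pair: with trifluoromethyl in place of chloro, there is a number 0.2 percentage points lower from compound 1 to compound 4 (within the scatter), so the two compounds cannot be told apart here. No measurement at hand explains why 4-acetylphenyl goes with the higher number.

Going by these compounds, it remains open whether the whole 4-acetylphenyl group matters or its aromatic ring alone would give the same reading, which a plain phenyl group on that nitrogen could settle. A carboxylic acid in place of the acetyl group would likewise test what that part of the substituent contributes.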